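Hydroxyl-bearing stereocentre in the fluorophenyl compound

The source may report more compounds than this note shows. Statements on the series, on what has been measured and on what is new or still open speak of the compounds shown alone.

Measured so far:
- compound 1 `COC(=O)C[C@H]1C[C@H](O)[C@@H](C)[C@@H](c2ccc(C)cc2)N1`: "not active" (no number reported)
- compound 2 `COC(=O)C[C@H]1C[C@@H](O)[C@@H](C)[C@@H](c2ccc(F)cc2)N1`: 19800 nM

For the measured compounds named here, in a functional assay on HeLa cells (Homo sapiens) for cytotoxicity, read by MTT assay (on this read-out lower numbers stand for stronger inhibition and higher numbers for weaker inhibition), compound 2 holds the only number, 19800 nM, while the other measured compound has none. Compound 3 `COC(=O)C[C@H]1C[C@H](O)[C@@H](C)[C@@H](c2ccc(F)cc2)N1` departs from compound 2 by one change: the two compounds have the same atoms and bonds and differ only in configuration as drawn: 1 of 4 stereo elements differ; a stereocentre at a saturated ring carbon is drawn R in compound 2 and S in compound 3. Going by the values given here, no measured step shows what such a change does. A modest shift toward weaker inhibition is expected, possibly nothing beyond the scatter. A result without a number also remains possible, as compound 1 gave "not active" (no number reported). The estimated step is a 1.5-fold higher number from compound 2 to compound 3 (0.18 log units; within the scatter). The expected value for compound 3 is 30000 nM, with an estimated range of 10000 nM to 80000 nM.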

Compound 3, half-maximal inhibitory concentration: 17400 nM
Compound 3: the middle estimate sits 1.7-fold (0.24 log units) above what was measured, and the stated range covers the measured number.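

In this assay, redrawing the stereocentre at a saturated ring carbon from R to S gives a 1.1-fold lower number from compound 2 to compound 3 (0.06 log units; within the scatter), so the two compounds cannot be told apart on this read-out. The comparison isolates configuration at this one centre: the fact that compounds 2 and 3 differ only in the configuration as drawn. Compound 3 has the configuration drawn as in compound 1, and compound 1 gives "not active" (no number reported), so this configuration alone does not account for the missing number.

Still open, from the compounds shown here alone, is what the same change does at the other stereocentres. Also open, going by these compounds, is how a carboxylic acid in place of the methyl ester would read.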